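Flavone series: side-chain amine swap from compound 2

A few compounds are considered here, and "the series" means these few. Any claim that something is new, unique, unknown or untested is made for them only; others in the source may bear on it.

Two compounds of the shared core carry measured numbers in a functional assay on HepG2 cells (Homo sapiens) for cytotoxicity, read by MTT assay, with a stated time of 72 h; a higher number here means a weaker inhibitor, a lower number a stronger inhibitor. Compound 1 `COc1c(OCCCCN2CCN(C)CC2)cc(O)c2c(=O)cc(-c3ccc(Br)cc3)oc12` gives 2320 nM in this assay. Compound 2 `CN1CCN(CCCOc2c(OCc3ccccc3)cc(O)c3c(=O)cc(-c4ccccc4)oc23)CC1` gives 3110 nM in this assay. Among the measured compounds shown here, the two numbers lie within the usual scatter of each other, so the data so far do not separate compound 2 from compound 1, and no step between them is counted.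

Compound 3 `O=c1cc(-c2ccccc2)oc2c(OCCCCN3CCCC3)c(OCc3ccccc3)cc(O)c12` has not yet been measured in this assay. Against compound 2 the change is (pyrrolidin-1-yl)methyl in place of 4-methylpiperazin-1-yl on a saturated chain carbon, three bonds along the chain from an oxygen on an aromatic ring. For the measured compounds named here, the measured pair gives no step that bears on an exchange of the terminal amine, so nothing here points to a direction; the expectation is a step of none beyond the scatter, and the estimated step from compound 2 to compound 3 in this assay is a 1.0-fold lower number from compound 2 to compound 3 (0.02 log units; within the scatter). Compound 3 is therefore expected to give about 3000 nM in this assay, with a range from 1200 nM to 8000 nM.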

Compound 3, half-maximal inhibitory concentration: 4660 nM
Compound 3: middle estimate off by 1.6-fold (0.19 log units), on the low side; low and high end bracket the measured number.
By their numbers in this assay, from the lowest: compounds 1, 2 and 3 (each within the scatter of the next).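

In this assay, among the compounds shown here, the exchange of 4-methylpiperazin-1-yl for (pyrrolidin-1-yl)methyl on a saturated chain carbon, three bonds along the chain from an oxygen on an aromatic ring, reads as a 1.5-fold higher number from compound 2 to compound 3 (0.18 log units; within the scatter) and is the first step that differs in one place. On this evidence, 3-(4-methylpiperazin-1-yl)propyl and 4-(pyrrolidin-1-yl)butyl are not separated in this read-out, even though the exchange alters the ring and the length of the chain together and removes one ring nitrogen. Nothing measured alongside these compounds offers an explanation for the step.

For the compounds shown here, the single exchange does not divide the part played by the ring from that of the chain, so 3-(pyrrolidin-1-yl)propyl on the same core would be needed to read each separately. Also open, on these data alone, is whether a different terminal group on the 3-carbon or 4-carbon chain, such as morpholin-4-yl, dimethylamino or a primary amine, would give a step beyond the scatter at this position.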